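A few compounds are considered here, and "the series" means these few. Any claim that something is new, unique, unknown or untested is made for them only; others in the source may bear on it.

Compound 1 `O=C(COc1ccc2cc(C(O)(C(F)(F)F)C(F)(F)F)c(O)cc2c1)Nc1nc2ccccc2s1` carries a 1,3-benzothiazol-2-yl group on its amide-type nitrogen; in an assay on isolated protein for inhibition of receptor-type tyrosine-protein phosphatase C (Homo sapiens), read by spectrophotometry (a lower number here means a stronger inhibitor, a higher number a weaker inhibitor), compound 1 gives 10900 nM. Compound 2 `O=C(COc1ccc2cc(C(O)(C(F)(F)F)C(F)(F)F)c(O)cc2c1)Nc1ccccc1` has a phenyl in that place instead. In this assay compound 2 reaches only a limit, > 20000 nM, not a number. That puts it at the limit of > 20000 nM in this assay, at which 1 of the 2 values shown sits, so where compound 2 stands is known only as a range. Within the data shown here, the one measured step, an at least 1.8-fold higher number from compound 1 to compound 2 (0.26 log units; that floor lies within the scatter), runs into that same limit and sits within the scatter at its floor, so it shows no clear change either way. Compound 3 `CCCNC(=O)COc1ccc2cc(C(O)(C(F)(F)F)C(F)(F)F)c(O)cc2c1` arises from compound 2 by propyl in place of phenyl on an amide-type nitrogen. Among the measured compounds shown here, no measured step tests this change, so the expectation rests on the limit alone. For compound 3 a value near that limit is therefore expected, with a step that the limit leaves unreadable from compound 2 to compound 3. The estimate for compound 3 in this assay is 25000 nM, with a range from 8000 nM to 80000 nM.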

Compound 3, half-maximal inhibitory concentration: > 20000 nM
Compound 3 ended at the assay's limit; the forecaster's own chance of this, stated with the estimate: 65%; the middle value does not contradict the limit.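

In this assay compound 3 gives > 20000 nM, which is a limit and not a number. So a propyl chain with no ring, like the phenyl ring of compound 2, leaves the value at that limit, and the only number among these compounds still belongs to the one carrying 1,3-benzothiazol-2-yl, yet the new comparison is an at least 1.8-fold higher number from compound 1 to compound 3 (0.26 log units; that floor lies within the scatter), so it shows no clear change either way. The step between compound 2 and compound 3 cannot be read, as both values are limits: the limit of > 20000 nM in this assay, at which 2 of the 3 values shown sit.

As far as these compounds go, how far compound 2 and compound 3 actually lie from compound 1 remains unknown. From the compounds shown here alone, it is also open whether a longer chain such as octyl, or a chain ending in an amine or a carboxylic acid, would give a number on this amide nitrogen.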